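Two limits and a third aryl amide on the shared core

This account rests on a few compounds, and the source may have more. Where it says the series, first, only, none or still open, it means among the compounds named here.

Compound 2 `COc1ccc(-c2cnc(NC(=O)c3cccc(C)c3)n2C)cc1`: > 100000 nM
Compound 1 `COc1ccc(-c2cnc(NC(=O)c3ccno3)n2C)cc1`: > 100000 nM

Compound 2 carries a 3-methylphenyl on the carbonyl carbon of the shared core. In a toxicity assay on THP-1 cells (Homo sapiens) for inhibition (on this read-out lower numbers stand for higher toxicity in this test and higher numbers for lower toxicity in this test), compound 2 gives > 100000 nM, and this is a limit of the test, not a number. Compound 1 differs only in the 1,2-oxazol-5-yl on that carbonyl carbon. In this assay compound 1 gives > 100000 nM, again a limit rather than a number. The step that the two limits leave unreadable from compound 1 to compound 2 therefore cannot be read in size or direction, because of the limit of > 100000 nM in this assay, at which 2 of the 2 values shown sit.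

Compound 3 `COc1ccc(-c2cnc(NC(=O)c3ccc(Cl)cc3)n2C)cc1` is not yet measured. Against compound 2 the change is 4-chlorophenyl in place of 3-methylphenyl on a carbonyl carbon. For the measured compounds named here, no measured step bears on this change with a readable size, and the only evidence is the shared limit described by the limit of > 100000 nM in this assay, at which 2 of the 2 values shown sit. Compound 3 is therefore expected to land at the same limit, so the step that the limit leaves unreadable from compound 2 to compound 3 is estimated to be none beyond the scatter. Compound 3 is expected to give about 150000 nM in this assay, within 50000 nM to 500000 nM.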

Compound 3, half-maximal cytotoxic concentration: > 100000 nM
Compound 3: no number, only a limit; the forecaster's own chance of this, stated with the estimate: 80%; the middle value lies beyond the limit too.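

In this assay compound 3 gives > 100000 nM, a limit and not a number. For the compounds shown here, no new step between compound 3 and compound 1 or compound 2 can therefore be read: the limit of > 100000 nM in this assay, at which 3 of the 3 values shown sit. The compounds shown leave open whether any group on the carbonyl carbon of the shared core would give a readable number in this assay.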